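Removing the hydroxymethyl from the amino acid side chain

The source may report more compounds than this note shows. Statements on the series, on what has been measured and on what is new or still open speak of the compounds shown alone.

Measured so far in a functional assay on the whole organism (Tail, strain ICR) with Mus musculus as the target, in the tail flick test, with a stated time of 30 min, at a dose of 25 umol/kg by the oral route; a lower number here means a weaker effect, a higher number a stronger effect of the compound at the dose given:
- compound 1, `O=C(O)[C@@H]1CCCN1C(=O)CN(c1nc(Cl)nc2[nH]cnc12)C1CC1`, gives 31.5%
- compound 2, `O=C(CN(c1nc(Cl)nc2[nH]cnc12)C1CC1)NCC(=O)OCc1ccccc1`, gives 18.7%
- compound 3, `O=C(CN(c1nc(Cl)nc2[nH]cnc12)C1CC1)N[C@@H](CO)C(=O)O`, gives 38.7%

The value of compound 3 and that of compound 1 lie within the scatter of each other, while the value of compound 2 lies beyond the scatter and lower. Compound 4, `O=C(O)CNC(=O)CN(c1nc(Cl)nc2[nH]cnc12)C1CC1`, is not yet measured. It differs from compound 3 in one place: hydrogen in place of hydroxymethyl on a saturated chain carbon bound to an amide-type nitrogen and a carbonyl carbon. Among the measured compounds shown here, the only measured step that changes the amino acid part of the amide is a number 7.2 percentage points higher from compound 1 to compound 3 (within the scatter), a change of a different amino acid that left the read-out essentially where it was. For the measured compounds named here, compound 2 carries a carboxymethyl group as its benzyl ester rather than the free acid, so no single step connects it to compound 4; its value only shows that an ester in this part of the molecule gave a lower number. On that basis the expected step is a number 5.7 percentage points lower from compound 3 to compound 4 (within the scatter), that is, no change beyond the scatter. Compound 4 is therefore estimated at 33%, with a range from 18% to 48%.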

Compound 4, a percentage reported as activity, at one dose (the size of the read-out at that dose, not a potency): 32.2%
Estimate against measurement, compound 4: 0.8 percentage points above; the measured number falls inside the stated range.
By their numbers in this assay, from the lowest: compound 2; then compounds 1, 4 and 3 (each within the scatter of the next).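

In this assay, hydrogen in place of hydroxymethyl on a saturated chain carbon bound to an amide-type nitrogen and a carbonyl carbon leaves the read-out within the scatter (a number 6.5 percentage points lower from compound 3 to compound 4 (within the scatter)), and the same holds when (carboxymethyl)amino stands in place of 2-carboxypyrrolidin-1-yl (a number 0.7 percentage points higher from compound 1 to compound 4 (within the scatter)). Neither the hydroxymethyl nor the 2-carboxypyrrolidin-1-yl group is therefore required for a read-out of this size at the dose given. Hydrogen in place of benzyl on an oxygen next to a carbonyl group gives a direct ester-to-acid comparison for the first time, and this step lies beyond the scatter (a number 13.5 percentage points higher from compound 2 to compound 4 (beyond the scatter)).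

No measurement is available to explain these steps.

Going by these compounds, whether a methyl group, a longer chain or an amine on that carbon would keep the read-out remains open. So does whether an amide or a methyl ester could replace the carboxylic acid.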